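The compounds below may be only part of what the source reports. "The series", "measured", "known", "first", "only" and "open" are said of these compounds alone.

Measured so far:
compound 1 `Cc1nc2c(OCc3ccccc3)cccn2c1Cl` — 37%
compound 2 `CCCCC(=O)OCc1c(C)nc2c(OCc3ccccc3)cccn12` — 96%

In a functional assay on the whole organism (stomach) for inhibition, with Canis familiaris (Canis lupus familiaris) as the target, at a dose of 5 mg/kg by the intravenous route (on this read-out higher numbers stand for a stronger effect at the one dose given and lower numbers for a weaker effect), compound 2 gives 96%, the higher of the two numbers shown, while compound 1 gives 37%. Among the compounds with values here, the only measured step is a number 59 percentage points higher from compound 1 to compound 2 (beyond the scatter). Compound 3 `Cc1nc2c(OCc3ccccc3)cccn2c1COC(=O)N(C)C` differs from compound 2 by dimethylamino in place of butyl on a carbonyl carbon. Within the data shown here, no measured step alters the group on the carbonyl carbon, so that step bears only indirectly: it shows the gain from installing the acyloxymethyl group, which compound 3 keeps as ((dimethylcarbamoyl)oxy)methyl. The expected step is a number 11 percentage points lower from compound 2 to compound 3 (beyond the scatter), within the scatter or slightly downward. Compound 3 is estimated at 85% (range 60% to 100%).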

Compound 3, a percentage reported as inhibition, in the whole organism at one dose (the size of the read-out at that dose, not a potency): 23%
For compound 3 the middle estimate is 62 percentage points above the measured one, and the stated range ends above it.
By their numbers in this assay, from the lowest: compound 3; then compound 1; then compound 2.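

The earlier step credited the gain to the acyloxymethyl group as a whole, but the effect depends on what the carbonyl carbon carries: dimethylamino in place of butyl gives a number 73 percentage points lower from compound 2 to compound 3 (beyond the scatter) in this series. Keeping the oxymethyl link is therefore not enough, as ((dimethylcarbamoyl)oxy)methyl in place of chloro gives a number 14 percentage points lower from compound 1 to compound 3 (beyond the scatter) and does not retain the gain seen with ((butylcarbonyl)oxy)methyl. As far as these compounds go, with one ester and one carbamate in hand, it remains open whether a methoxy group, a methyl group or a longer chain on the carbonyl carbon would stay near the butyl result. What lies behind the loss also stays open, since no measurement bears on it.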